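Dropping Two Methoxy Groups from a Bis(trifluoromethyl)sulfonamide

The compounds below may be only part of what the source reports. "The series", "measured", "known", "first", "only" and "open" are said of these compounds alone.

Two sulfonamides have been tested in a functional assay on A2780 cells (Homo sapiens) for inhibition, read by MTT assay, with a stated time of 72 h; on this read-out lower numbers stand for stronger inhibition of growth and higher numbers for weaker inhibition of growth. Compound 1 `O=S(=O)(NCCNCc1ccc(-c2ccccc2)cc1)c1cc(C(F)(F)F)cc(C(F)(F)F)c1` gives 2600 nM in this assay, and compound 2 `COc1ccc(CNCCCNS(=O)(=O)c2cc(C(F)(F)F)cc(C(F)(F)F)c2)cc1OC` gives 3800 nM; the two numbers lie within the usual scatter of each other, so neither can be called the more active. Compound 3 `O=S(=O)(NCCCNCc1ccccc1)c1cc(C(F)(F)F)cc(C(F)(F)F)c1` has not yet been measured in this assay. It differs from compound 2 by phenyl in place of 3,4-dimethoxyphenyl on a saturated chain carbon bound to an amine nitrogen. Among the measured compounds shown here, with no comparable step in hand, the expected step from compound 2 to compound 3 in this assay is a 1.2-fold higher number from compound 2 to compound 3 (0.07 log units; within the scatter), which is not beyond the scatter. Compound 3 is therefore estimated at 4500 nM in this assay, within 1500 nM to 13000 nM.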

Compound 3, concentration for 50% growth inhibition: 4900 nM
For compound 3 the middle estimate is 1.1-fold (0.04 log units) below the measured one; low and high end bracket the measured number.
By their numbers in this assay, from the lowest: compounds 1, 2 and 3 (each within the scatter of the next).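

In this assay, phenyl in place of 3,4-dimethoxyphenyl gives a 1.3-fold higher number from compound 2 to compound 3 (0.11 log units; within the scatter) and so leaves the two compounds indistinguishable. At this position, on a saturated chain carbon bound to an amine nitrogen, the two methoxy groups therefore show no measurable contribution to growth inhibition on this read-out. No measurement at hand accounts for this result.

From the compounds shown here alone, it remains open whether a single methoxy group, a hydroxyl or a nitrile on the phenyl ring would shift the number. Going by these compounds, whether a longer chain would do so is also open.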